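A few compounds are considered here, and "the series" means these few. Any claim that something is new, unique, unknown or untested is made for them only; others in the source may bear on it.

Three compounds built on the shared core of compound 1 `COc1cc(N(Cc2nc3ccccc3[nH]2)S(=O)(=O)c2ccc(C)cc2)cc(OC)c1OC` have been tested in a functional assay on MGC-803 cells (Homo sapiens) for inhibition, read by MTT assay, with a stated time of 48 h; on this read-out higher numbers stand for weaker inhibition and lower numbers for stronger inhibition. Compound 1 gives 1020 nM. Compound 2 `COc1cc(N(Cc2nc3ccccc3[nH]2)S(=O)(=O)c2ccccc2)cc(OC)c1OC` gives 12400 nM in this assay, and compound 3 `COc1cc(N(Cc2nc3ccccc3[nH]2)C(=O)c2ccc(F)cc2)cc(OC)c1OC` gives 23600 nM. Compound 3 thus carries the highest of the three numbers: it sits within the scatter of compound 2, while its distance to compound 1 is beyond the scatter, a 23-fold higher number from compound 1 to compound 3 (1.36 log units; beyond the scatter).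

Compound 4 `COc1ccc(C(=O)N(Cc2nc3ccccc3[nH]2)c2cc(OC)c(OC)c(OC)c2)cc1OC` differs from compound 3 in one place: 3,4-dimethoxyphenyl in place of 4-fluorophenyl on a carbonyl carbon. Among the measured steps, the one most like this is the change of a substituent on an aromatic carbon, a 12-fold higher number from compound 1 to compound 2 (1.08 log units; beyond the scatter), which was large. The other step, a 1.9-fold higher number from compound 2 to compound 3 (0.28 log units; within the scatter), exchanges the sulfonyl for a carbonyl and bears only indirectly on the aryl group entering here. A step beyond the scatter in this assay is therefore plausible for compound 4, but a single example gives no reliable direction, so the expectation stays near the present number with a wide range. Compound 4 is estimated at 15000 nM, between 4000 nM and 60000 nM. This estimate corresponds to an expected step of a 1.6-fold lower number from compound 3 to compound 4 (0.20 log units; within the scatter).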

Compound 4, half-maximal inhibitory concentration: 22400 nM
Compound 4: middle estimate off by 1.5-fold (0.17 log units), on the low side; the measured number falls inside the stated range.
By their numbers in this assay, from the lowest: compound 1; then compounds 2, 4 and 3 (each within the scatter of the next).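

On the carbonyl carbon, 3,4-dimethoxyphenyl in place of 4-fluorophenyl leaves the number in this assay within the scatter (a 1.1-fold lower number from compound 3 to compound 4 (0.02 log units; within the scatter)), although the entering group has 10 heavy atoms and 2 hydrogen-bond acceptors against 7 heavy atoms and 0 hydrogen-bond acceptors in the group that leaves. For the compounds shown here, the earlier compounds showed a large response to a change on an aryl group only on the sulfonyl side (a 12-fold higher number from compound 1 to compound 2 (1.08 log units; beyond the scatter)), so this pair adds the first comparison of two aryl groups on the carbonyl, and these two groups are not told apart by this read-out. No measurement on these compounds is available that would explain this result.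

The compounds shown leave open whether 4-methylphenyl on the carbonyl carbon would bring the number close to that of the sulfonyl compound 1 (1020 nM), or whether the large step seen on the sulfonyl side is confined to that side. They also leave open how the carbonyl compounds would respond to an amine or a carboxylic acid on this aromatic ring, or to a longer alkyl chain in place of the aryl group.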